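Working notes on the methyl-for-chloro step

The compounds below may be only part of what the source reports. "The series", "measured", "known", "first", "only" and "open" are said of these compounds alone.

Compound 1 `COc1cccc(Cn2cnc3sc(-c4ccc5[nH]ncc5c4)cc3c2=O)c1` gives 20 nM in an assay on isolated protein for inhibition of Rho-associated protein kinase 1 (Homo sapiens), read by radiometric assay and 33P incorporation, with a stated time of 40 min, in the presence of a further agent that is not named here; a higher number here means a weaker inhibitor, a lower number a stronger inhibitor. Compound 2 `COc1cccc(Cn2cnc3sc(-c4ccnc(F)c4)cc3c2=O)c1` gives 1050 nM in this assay, a shift of a 53-fold higher number from compound 1 to compound 2 (1.72 log units; beyond the scatter). Compound 3 `COc1cccc(Cn2cnc3sc(-c4ccnc(Cl)c4)cc3c2=O)c1` reaches only the assay limit, > 10000 nM. The step of an at least 500-fold higher number from compound 1 to compound 3 (2.69 log units; beyond the scatter) and the step of an at least 9.5-fold higher number from compound 2 to compound 3 (0.97 log units; beyond the scatter) are therefore lower bounds, and compound 3 sits at the weak end of the three numbers (the limit of > 10000 nM in this assay, at which 1 of the 3 values shown sits). Compound 4 `COc1cccc(Cn2cnc3sc(-c4ccnc(C)c4)cc3c2=O)c1` carries methyl in place of chloro on an aromatic carbon. Going by the values given here, the only measured step that bears on it is an at least 9.5-fold higher number from compound 2 to compound 3 (0.97 log units; beyond the scatter), an exchange of one halogen for another; no measured step exchanges a halogen for methyl. A lower number in this assay is expected for compound 4, its size uncertain against a limit, an at least 2.0-fold lower number from compound 3 to compound 4 (0.30 log units; that floor lies within the scatter). Compound 4 is estimated at 5000 nM, within 800 nM to 30000 nM.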

Compound 4, half-maximal inhibitory concentration: 2520 nM
Beside the measured number, compound 4's estimate is 2.0-fold (0.30 log units) above it; the range from low to high includes it.
By their numbers in this assay, from the lowest: compound 1; then compound 2; then compound 4. At a limit, above all of these: compound 3.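

Compound 3 stands only at a limit in this assay: the limit of > 10000 nM in this assay, at which 1 of the 4 values shown sits. Methyl in place of chloro gives an at least 3.9-fold lower number from compound 3 to compound 4 (0.59 log units; beyond the scatter), a lower bound, while methyl in place of fluoro gives a 2.4-fold higher number from compound 2 to compound 4 (0.38 log units; beyond the scatter), so that at this place the number rises from fluoro to methyl to chloro. The 2-methylpyridin-4-yl group still leaves a 130-fold higher number from compound 1 to compound 4 (2.10 log units; beyond the scatter) against the 1H-indazol-5-yl group.

Open, from the compounds shown here alone, is whether an amine or a methoxy group at this place would narrow that gap to compound 1. Also open, going by these compounds, is whether the order of fluoro, methyl and chloro holds on any other core.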